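From (4-bromophenyl)amino to dipropylamino on the shared core

The source may report more compounds than this note shows. Statements on the series, on what has been measured and on what is new or still open speak of the compounds shown alone.

Compound 1 `O=C1C(Nc2ccc(Br)cc2)=CC(=O)c2c1nc1n2[C@H]2OC[C@@H](O)[C@H]2OC1` carries a (4-bromophenyl)amino group on its core. In a functional assay on MGC-803 cells (Homo sapiens) for inhibition, read by sulforhodamine B assay (on this read-out higher numbers stand for weaker inhibition and lower numbers for stronger inhibition), compound 1 gives 2020 nM, the lowest of the two numbers shown. Compound 2 `O=C1C=C(Nc2ccc(C(F)(F)F)cc2)C(=O)c2c1nc1n2[C@H]2OC[C@@H](O)[C@H]2OC1` gives 2820 nM in this assay, within the scatter of compound 1. Compound 3 `O=C1C=C(N2CCCCC2)C(=O)c2c1nc1n2[C@H]2OC[C@@H](O)[C@H]2OC1`, whose substituent has no hydrogen-bond donor, reaches only a limit of the assay, > 8000 nM. Compound 4 `CCCN(CCC)C1=CC(=O)c2c(nc3n2[C@H]2OC[C@@H](O)[C@H]2OC3)C1=O` differs from compound 1 by dipropylamino in place of (4-bromophenyl)amino on a double-bonded ring carbon. Within the data shown here, no measured step of this kind exists, but the limit seen for compound 3 the limit of > 8000 nM in this assay, at which 1 of the 3 values shown sits, suggests that a change which again removes the hydrogen-bond donor is expected to weaken inhibition beyond the scatter. Compound 4 is therefore expected near 9000 nM, between 3500 nM and 20000 nM. The estimated step is a 4.5-fold higher number from compound 1 to compound 4 (0.65 log units; beyond the scatter).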

Compound 4, half-maximal inhibitory concentration: > 16000 nM
Compound 4: only a limit was reported; the forecaster's own chance of this, stated with the estimate: 60%; middle value at least 1.7-fold (0.24 log units) from the limit.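

In this assay, dipropylamino in place of (4-bromophenyl)amino on this double-bonded ring carbon gives an at least 7.9-fold higher number from compound 1 to compound 4 (0.89 log units; beyond the scatter). Compound 4 stands only at a limit of the assay: the limit of > 16000 nM in this assay, at which 1 of the 4 values shown sits. Compound 4 thus joins compound 3 as a second compound with no hydrogen-bond donor that stops at a limit, now with an open chain, while compounds 1 and 2 keep the donor and give numbers.

Two limits cannot be ranked, so compounds 3 and 4 cannot be ordered. Dipropylamino removes the aromatic ring and the donor together, and a propylamino group, which keeps the amine hydrogen without a ring, remains open.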